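Replacing hydroxy with (dimethylamino)methyl: effect on plasma protein binding

The compounds below may be only part of what the source reports. "The series", "measured", "known", "first", "only" and "open" are said of these compounds alone.

In an ADME assay on a cell-free system (plasma, Homo sapiens) for protein binding, with Plasma (Rattus norvegicus) as the target, compound 1 `COc1c(NC(=O)c2ccc(C)c(N3C=C(C(=O)NCC(C)(C)C)NN3)c2)cc(C(C)(C)C)cc1NS(C)(=O)=O` gives 92% and compound 2 `COc1c(NC(=O)c2ccc(C)c(N3C=C(C(=O)NCC(C)(C)O)NN3)c2)cc(C(C)(C)C)cc1NS(C)(=O)=O` gives 66%. Compound 2 therefore has the larger free share of these two measured compounds. They differ in one place, with hydroxy in place of methyl on a saturated chain carbon bound to three saturated chain carbons, and the numbers show a 4.3-fold higher unbound fraction from compound 1 to compound 2 (0.63 log units; beyond the scatter).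

Compound 3 `COc1c(NC(=O)c2ccc(C)c(N3C=C(C(=O)NCC(C)(C)CN(C)C)NN3)c2)cc(C(C)(C)C)cc1NS(C)(=O)=O` changes that same place again: (dimethylamino)methyl in place of hydroxy on a saturated chain carbon bound to three saturated chain carbons. The hydroxy of compound 2 leaves, and (dimethylamino)methyl enters. Going by the values given here, only one measured step bears on this change, the modest a 4.3-fold higher unbound fraction from compound 1 to compound 2 (0.63 log units; beyond the scatter), which involves the same hydroxy on the same carbon. Among the compounds with values here, it is a single pair, and no measured compound carries (dimethylamino)methyl, so the guide is thin. Losing the hydroxy is expected to give back part of that step, but not necessarily all of it. The expected change, in the direction of more binding, is estimated as a 2.3-fold lower unbound fraction from compound 2 to compound 3 (0.36 log units; beyond the scatter). In this assay, the estimate for compound 3 is 85%, expected to lie between 72% and 94%.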

Compound 3, plasma protein binding in the Plasma assay: 66%
For compound 3 the middle estimate is 2.3-fold (0.36 log units) (unbound fraction) below the measured one, outside the stated range (below it).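

Going by these compounds alone, the measured result shows that the hydroxy is not the only group at this place that goes with a larger free share in the Plasma assay: the step to (dimethylamino)methyl reads no change at the digits printed from compound 2 to compound 3 (within the scatter) and leaves plasma protein binding where it was. Measured against the purely carbon end of compound 1, the step is a 4.3-fold higher unbound fraction from compound 1 to compound 3 (0.63 log units; beyond the scatter) and compound 3 keeps the gain seen for compound 2, although the group entering has 0 hydrogen-bond donors where the hydroxy has 1, so a donor at this place is not needed for that free share. The swap does separate the two compounds in a physicochemical assay for solubility, at pH 7.4 (a higher number here means a more soluble compound, a lower number a less soluble compound), where compound 2 gives 2 ug/mL and compound 3 gives 13.9 ug/mL and is the more soluble, so this change brings a solubility gain with no measured cost in binding: the measured solubility of compound 2, 2 ug/mL, and of compound 3, 13.9 ug/mL, a 7.0-fold higher number (0.84 log units; beyond the scatter).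

The compounds shown leave open how far the free share can move at this carbon, for instance with a carboxylic acid in the same place. They also cannot tell whether the nitrogen itself matters for either read-out, a question that a methoxymethyl group on the same carbon would address.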